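A few compounds are considered here, and "the series" means these few. Any claim that something is new, unique, unknown or untested is made for them only; others in the source may bear on it.

Series notes. Compound 3 `c1ccc(C(c2ccccc2)n2cc(C3CCCCC3)nn2)cc1` gives 13700 nM in an assay on isolated protein for inhibition of Aromatase (Homo sapiens), read by fluorescence and colorimetric assay, with a stated time of 30 min (a higher number here means a weaker inhibitor, a lower number a stronger inhibitor), and stands second highest of the three numbers, near compound 2 `CCCc1cn(C(c2ccccc2)c2ccccc2)nn1` at 11000 nM and compound 1 `N#Cc1ccc(C(c2ccc(C#N)cc2)n2cc(C3CCCCC3)nn2)cc1` at 19300 nM, both within the scatter. Compound 4 `Cc1ccc(OCc2cn(C(c3ccccc3)c3ccccc3)nn2)cc1` differs from compound 3 by (4-methylphenoxy)methyl in place of cyclohexyl on an aromatic carbon. Among the measured compounds shown here, the only measured step at an aromatic carbon of this ring, a 1.2-fold higher number from compound 2 to compound 3 (0.10 log units; within the scatter), stayed within the scatter; no measured step swaps a carbon-only ring for a group with a hydrogen-bond acceptor, so direct bearing is absent. The change is therefore expected to move this assay little, if at all, beyond the scatter. Compound 4 is estimated at 11000 nM, with a range from 3500 nM to 35000 nM, meaning an expected step of a 1.2-fold lower number from compound 3 to compound 4 (0.10 log units; within the scatter).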

Compound 4, half-maximal inhibitory concentration: 26800 nM
For compound 4 the middle estimate is 2.4-fold (0.39 log units) below the measured one, within the range that was stated.
By their numbers in this assay, from the lowest: compounds 2, 3, 1 and 4 (each within the scatter of the next, the first and the last beyond it).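

At this aromatic carbon, the change from cyclohexyl to (4-methylphenoxy)methyl, which brings in a hydrogen-bond acceptor, gives (a 2.0-fold higher number from compound 3 to compound 4 (0.29 log units; within the scatter)) and so stays within the scatter. Among the compounds shown here, measured against the propyl of compound 2, the same group gives (a 2.4-fold higher number from compound 2 to compound 4 (0.39 log units; beyond the scatter)), the only modest step at this carbon beyond the scatter. Nothing available bears on the reason for either step. The compounds shown leave open how an amine or a carboxylic acid at this carbon would read, and whether (4-methylphenoxy)methyl would behave alike on the core of compound 1.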